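Fluoro for Chloro: A Small Change to Compound 3

The source may hold more compounds than are shown below. What is called first, only, known or untested is meant among the compounds shown, and "the series" means these compounds.

Of the compounds shown here, three sharing one core have been measured in an assay for inhibition of Indoleamine 2,3-dioxygenase 1 (Homo sapiens), read by HPLC, with a stated time of 48 h; on this read-out lower numbers stand for stronger inhibition and higher numbers for weaker inhibition. Compound 1 `O=C(NCc1cccc(Cn2cnc3ccccc32)c1)c1cc2cc(O)ccc2[nH]1` gives 781 nM. Compound 2 `O=C(NCc1cccc(Cn2cnc3ccccc32)c1)c1nc2ccccc2[nH]1` gives 407 nM. Compound 3 `O=C(NCc1cccc(Cn2cnc3ccccc32)c1)c1ccc(Cl)cc1` gives 477 nM. Among these three numbers compound 3 sits second highest: its nearest neighbour is compound 2 (a 1.2-fold higher number from compound 2 to compound 3 (0.07 log units; within the scatter)), and the furthest is compound 1 (a 1.6-fold lower number from compound 1 to compound 3 (0.21 log units; within the scatter)). The remaining pair moves a 1.9-fold lower number from compound 1 to compound 2 (0.28 log units; within the scatter). All three steps stay within the usual scatter, so nothing here separates the three compounds with confidence.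

Compound 4 `O=C(NCc1cccc(Cn2cnc3ccccc32)c1)c1ccc(F)cc1` has not yet been measured. It differs from compound 3 by fluoro in place of chloro on an aromatic carbon. Among the measured compounds shown here, none of the measured steps touches a halogen; each of them exchanges the whole group on the carbonyl carbon, and even those larger exchanges stayed within the scatter. A change that swaps one halogen for another at the same place is smaller still, so no step beyond the scatter is expected for compound 4 in this assay. Compound 4 is therefore estimated at 550 nM, with a range from 250 nM to 1200 nM. The step from compound 3 that this estimate implies is expected to be a 1.2-fold higher number from compound 3 to compound 4 (0.06 log units; within the scatter).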

Compound 4, half-maximal inhibitory concentration: 961 nM
For compound 4 the middle estimate is 1.7-fold (0.24 log units) below the measured one; low and high end bracket the measured number.
By their numbers in this assay, from the lowest: compounds 2, 3, 1 and 4 (each within the scatter of the next, the first and the last beyond it).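

In this assay, among the compounds shown here, fluoro in place of chloro on the aromatic carbon para to a large group gives a 2.0-fold higher number from compound 3 to compound 4 (0.30 log units; within the scatter) and so provides the first reading of a change at this position, although this exchange of one halogen for the other does not separate the two compounds with confidence. For the compounds shown here, with the fluoro group in place, swapping the whole group on the carbonyl carbon gives a 2.4-fold higher number from compound 2 to compound 4 (0.37 log units; beyond the scatter) as the first step in this small set to lie beyond the scatter, though only modestly, whereas the matching exchange with 4-chlorophenyl stayed within it. The other exchange, 4-fluorophenyl in place of 5-hydroxy-1H-indol-2-yl, gives a 1.2-fold higher number from compound 1 to compound 4 (0.09 log units; within the scatter) with no clear separation, and nothing available here accounts for any of these readings.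

The compounds shown leave open how a bromo group, a methoxy group, an amine or a plain hydrogen at this same place would read. They also leave open whether fluoro in place of chloro would give a similar step if the rest of the molecule were different.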